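The source may report more compounds than this note shows. Statements on the series, on what has been measured and on what is new or still open speak of the compounds shown alone.

Three compounds measured in an assay on cells for agonist activity at ecdysone receptor (Bombyx mori), read by a luciferase reporter, with a stated time of 24 h (on this read-out higher numbers stand for an effect only at larger amounts of compound and lower numbers for an effect already at smaller amounts), frame this account. Compound 1 `CC(C)(C)N(NC(=O)c1cccc(Cl)c1)C(=O)c1ccccc1Cl` gives 155 nM in this assay. Compound 2 `Cc1cccc(C(=O)NN(C(=O)c2ccccc2Cl)C(C)(C)C)c1` gives 603 nM. Compound 3 `Cc1ccc(C(=O)NN(C(=O)c2cc(C)cc(C)c2)C(C)(C)C)cc1` gives 12 nM, the lowest of the three numbers, and its gaps to compound 1 and to compound 2 both lie beyond the scatter.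

Compound 1 and compound 2 differ in one place only: chloro in place of methyl on an aromatic carbon. That change produced a 3.9-fold lower number from compound 2 to compound 1 (0.59 log units; beyond the scatter). How compound 3 differs from compound 2 is not broken down here beyond the fact that the two cores differ.

Compound 4 `Cc1cc(C)cc(C(=O)N(NC(=O)c2ccc(Cl)cc2)C(C)(C)C)c1` has not yet been measured. It differs from compound 3 by chloro in place of methyl on an aromatic carbon. Among the compounds with values here, this is the same kind of change as the one from compound 2 to compound 1, but not the same: around the place, the earlier exchange sits meta to a large group, while in compound 4 the chloro sits para to a large group.

Resting on the step from compound 2 to compound 1, a 3.9-fold lower number from compound 2 to compound 1 (0.59 log units; beyond the scatter), compound 4 is expected to show a step of about a 1.7-fold lower number from compound 3 to compound 4 (0.23 log units; within the scatter) from compound 3, with the surroundings of the place adding uncertainty. Compound 4 is therefore estimated at 7 nM, with a range from 2.5 nM to 20 nM.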

Compound 4, half-maximal effective concentration: 19.1 nM
Compound 4: middle estimate off by 2.7-fold (0.44 log units), on the low side; measured number inside the range.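

In this assay, putting chloro in place of methyl on the core of compound 3, on an aromatic carbon para to a large group, gave a 1.6-fold higher number from compound 3 to compound 4 (0.20 log units; within the scatter), so this pair cannot be told apart and the exchange has no readable effect here. The change therefore does not carry over from one core to the other with the size it had in the first pair: the same change on two cores in this assay, a 3.9-fold lower number (0.59 log units; beyond the scatter) from compound 2 to compound 1 and a 1.6-fold higher number (0.20 log units; within the scatter) from compound 3 to compound 4, 6.2-fold (0.79 log units) apart, beyond the scatter of two such steps. Within the data shown here, this shows only that the earlier step cannot be transferred as a fixed increment; the two pairs differ both in their cores and in the surroundings of the exchanged group, so two steps cannot say which of these accounts for the gap, and they give no rule for any further core.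

All the aromatic substituents shown are chloro or methyl, so it remains open what a methoxy group, a fluoro group or a nitrile would give at the same place in this assay. On these data alone, it is also open whether the same exchange, made at one fixed place on a third core, would follow the first pair, the second pair or neither.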